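Ethyl in Place of Cyclopropyl: Estimating Compound 4

A few compounds are considered here, and "the series" means these few. Any claim that something is new, unique, unknown or untested is made for them only; others in the source may bear on it.

Three compounds have been measured in a functional assay on CCRF-CEM cells for antagonist activity at C-X-C chemokine receptor type 4 (Homo sapiens), read by calcium flux, with stated times of 25 min and 90 s; on this read-out lower numbers stand for stronger inhibition and higher numbers for weaker inhibition:
compound 1, `Cc1cnc(CN(C)C[C@H]2Cc3c(cccc3N3CCNCC3)CN2)c(C)c1`, gives 21.4 nM;
compound 2, `CN(C[C@H]1Cc2c(cccc2N2CCN(C3CC3)CC2)CN1)[C@H]1CCCc2cccnc21`, gives 23.5 nM;
compound 3, `CN(C[C@H]1Cc2c(cccc2N2CCNC(C)(C)C2)CN1)[C@H]1CCCc2cccnc21`, gives 33.9 nM.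

Compound 2 holds the second highest of the three numbers. Its nearest neighbour is compound 1 and its furthest is compound 3, and both gaps lie within the scatter of the measurement, so the three compounds cannot be put in any order of potency on these data.

Compound 4, `CCN1CCN(c2cccc3c2C[C@H](CN(C)[C@H]2CCCc4cccnc42)NC3)CC1`, differs from compound 2 in one place: ethyl in place of cyclopropyl on an amine nitrogen in a ring. Among the measured compounds shown here, the one measured step that bears on this change is the one at the same ring, a 1.4-fold higher number from compound 2 to compound 3 (0.16 log units; within the scatter). That step replaced the whole ring substituent pattern and still stayed within the scatter; the present change is smaller, exchanging one small carbon group for another on the ring nitrogen. No step beyond the scatter is therefore expected in this assay.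

Compound 4 is expected to give 25 nM, with a range from 12 nM to 50 nM. The expected step is a 1.1-fold higher number from compound 2 to compound 4 (0.03 log units; within the scatter), a difference that would fall within the scatter.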

Compound 4, half-maximal inhibitory concentration: 13.8 nM
For compound 4 the middle estimate is 1.8-fold (0.26 log units) above the measured one; measured number inside the range.
By their numbers in this assay, from the lowest: compounds 4, 1, 2 and 3 (each within the scatter of the next, the first and the last beyond it).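

In this assay, the change from cyclopropyl to ethyl on the ring nitrogen gives a 1.7-fold lower number from compound 2 to compound 4 (0.23 log units; within the scatter) and so cannot be told apart from the measurement's scatter, which means this nitrogen carries either small carbon group with no readable difference. Among the compounds shown here, the step at the same place on the aromatic carbon, a 2.5-fold lower number from compound 3 to compound 4 (0.39 log units; beyond the scatter), is modest but is the first step here to pass beyond the scatter, so 4-ethylpiperazin-1-yl and 3,3-dimethylpiperazin-1-yl can be separated even though compound 2 lies within the scatter of both. No measurement at hand explains either step.

On these data alone, how far this tolerance extends remains open, since a longer chain such as propyl, or a hydroxyethyl or acetyl group on the same ring nitrogen, could behave quite differently from ethyl and cyclopropyl. It is also unsettled whether the separation of compound 3 from compound 4 comes from the ethyl group on the ring nitrogen or from the two methyl groups on the ring carbon, as the two groups differ in both identity and place.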